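A Long Ether Chain Shortened to Methyl

This account rests on a few compounds, and the source may have more. Where it says the series, first, only, none or still open, it means among the compounds named here.

In a functional assay on HL-60 cells (Homo sapiens) for cytotoxicity, read by WST assay, with a stated time of 48 h (on this read-out higher numbers stand for an effect only at larger amounts of compound and lower numbers for an effect already at smaller amounts), compound 1 `O=C1OC[C@H](Cc2ccccc2)[C@H]1Cc1ccc(OC(F)(F)F)cc1` gives 27000 nM as its reading. Compound 2 `CCCCCCCOc1ccc(C[C@H]2C(=O)OC[C@@H]2Cc2ccccc2)cc1` stands at > 100000 nM and that is a limit of this assay rather than a number, so only a bound on its position is known. Compound 3 `Cc1ccc(C[C@H]2C(=O)OC[C@@H]2Cc2ccccc2)cc1` differs from compound 2 in one place: methyl in place of heptyloxy on an aromatic carbon with methyl in place of heptyloxy on an aromatic carbon, para to a large group. Within the data shown here, one measured step bears on this change, namely an at least 3.7-fold higher number from compound 1 to compound 2 (0.56 log units; beyond the scatter) with heptyl in place of trifluoromethyl on an oxygen. That step lies beyond the scatter, and its size is bounded by the limit. Going by an at least 3.7-fold higher number from compound 1 to compound 2 (0.56 log units; beyond the scatter) as the only guide, the loss of the heptyloxy group is expected to bring a modest move towards lower numbers in this assay and not a large one. The expected change is an at least 2.5-fold lower number from compound 2 to compound 3 (0.39 log units; beyond the scatter) as estimated against a limit, and a reading at the limit again remains possible. For compound 3 the estimate is 40000 nM with an expected range from 15000 nM to 100000 nM as the likely span.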

Compound 3, half-maximal effective concentration: 44000 nM
The estimate for compound 3 lay 1.1-fold (0.04 log units) below the measured number, and the stated range covers the measured number.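

In this assay, among these compounds, methyl in place of heptyloxy on the aromatic carbon, para to a large group, gives the first direct reading of what removing the long ether chain does at this position, and the move is an at least 2.2-fold lower number from compound 2 to compound 3 (0.35 log units; beyond the scatter). The reading of compound 2 is a limit and not a number, so this step is only a bound: the limit of > 100000 nM in this assay, at which 1 of the 3 values shown sits.

Methyl in place of trifluoromethoxy gives a different picture, with a 1.6-fold higher number from compound 1 to compound 3 (0.21 log units; within the scatter), so these two groups cannot be told apart here, and among the three compounds only the heptyloxy group stands apart from the others.

The compounds shown leave open whether the reading of compound 2 follows the length of the chain or the presence of the ether oxygen, which a methoxy group or a heptyl chain at this place would help to separate. From the compounds shown here alone, it also remains open how an amine or a carboxylic acid at this position would read, and whether any group here would bring the number well under those of compound 1 and compound 3.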